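The compounds below may be only part of what the source reports. "The series", "measured", "known", "first", "only" and "open" are said of these compounds alone.

Compound 2, `CC(C)(C)CCC1([C@H](O)/C=C/[C@H]2COC(=O)N2CCSc2nc(C(=O)O)cs2)CCC1`, gives 4710 nM in an assay on isolated protein for agonist activity at prostaglandin E2 receptor EP4 subtype (Homo sapiens) (a higher number here means that more compound is needed for the effect, a lower number that less compound is needed), the highest of the two numbers here; its nearest neighbour is compound 1, `CCOCCC1([C@H](O)/C=C/[C@H]2COC(=O)N2CCSc2nc(C(=O)O)cs2)CCC1`, which gives 745 nM. For the measured compounds named here, the one measured step, a 6.3-fold higher number from compound 1 to compound 2 (0.80 log units; beyond the scatter), concerns the same place but a different change. Compound 3, `O=C(O)c1csc(SCCN2C(=O)OC[C@@H]2/C=C/[C@@H](O)C2(CCc3ccccc3)CCC2)n1`, differs from compound 2 by phenyl in place of tert-butyl on a saturated chain carbon, two bonds along the chain from a saturated ring carbon. Going by the values given here, no measured step tests a phenyl at this place, so the expectation rests loosely on that single step. Compound 3 is expected to give a somewhat lower number, 900 nM within 200 nM to 4000 nM, that is a 5.2-fold lower number from compound 2 to compound 3 (0.72 log units; beyond the scatter).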

Compound 3, half-maximal effective concentration: 465 nM
For compound 3 the middle estimate is 1.9-fold (0.29 log units) above the measured one; the range from low to high includes it.
By their numbers in this assay, from the lowest: compounds 3 and 1 (each within the scatter of the next); then compound 2.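

At this place on the chain, phenyl gives a far lower number than tert-butyl in this assay (a 10-fold lower number from compound 2 to compound 3 (1.01 log units; beyond the scatter)), so a ring carbon-only group of this kind is tolerated where the branched group is not. Phenyl and ethoxy cannot be told apart (a 1.6-fold lower number from compound 1 to compound 3 (0.20 log units; within the scatter)), which leaves tert-butyl as the one group of the three with a clearly higher number. Nothing measured here explains this difference. Still open, from the compounds shown here alone, is whether a pyridine ring, a substituted phenyl or a longer chain at this place would give a lower number.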